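This account rests on a few compounds, and the source may have more. Where it says the series, first, only, none or still open, it means among the compounds named here.

Compound 1 `N#Cc1c(N)nc(SCc2cccnc2)c(C#N)c1-c1ccc(OCC2CC2)cc1`: 19%
Compound 2 `CCOc1ccc(-c2c(C#N)c(N)nc(SCc3ccn[nH]3)c2C#N)cc1`: 18%
Compound 3 `CC(C)COc1ccc(-c2c(C#N)c(N)nc(SCC(N)=O)c2C#N)cc1`: 9%

These three were tested in an assay on CHO cells for displacement of a labelled ligand from adenosine receptor A3 (Homo sapiens), read by scintillation counting, with a stated time of 120 min, tested at 1 uM; on this read-out higher numbers stand for more inhibition at the one concentration tested (going by the name of the read-out) and lower numbers for less inhibition. The number for compound 1 is nominally the highest of the three, but compound 2 and compound 3 both lie within the usual scatter of it, so the three cannot be told apart; all sit at low inhibition. Compound 4 `COC(=O)c1cccc(CSc2nc(N)c(C#N)c(-c3ccc(OCC4CC4)cc3)c2C#N)c1` has not yet been measured. It differs from compound 1 in one place: 3-(methoxycarbonyl)phenyl in place of pyridin-3-yl on a saturated chain carbon bound to a sulfur. Among the measured compounds shown here, no measured pair shows this change, so nothing is known about its effect, and the three compounds, which differ in several places, all give low numbers that do not separate. Compound 4 is therefore expected to stay near compound 1, with a step of a number 1 percentage points higher from compound 1 to compound 4 (within the scatter) that is not expected to go beyond the scatter. The estimate for compound 4 is 20%, with a range from 5% to 40%.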

Compound 4, a percentage reported as inhibition, at one concentration (the size of the read-out at that concentration, not a potency): 4%
Beside the measured number, compound 4's estimate is 16 percentage points above it; measured number outside the range, below it.
By their numbers in this assay, from the lowest: compounds 4, 3, 2 and 1 (each within the scatter of the next, the first and the last beyond it).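

In this assay, 3-(methoxycarbonyl)phenyl in place of pyridin-3-yl on a saturated chain carbon bound to a sulfur gives a number 15 percentage points lower from compound 1 to compound 4 (beyond the scatter). Among the compounds shown here, this is the first sign that the group at this position can shift the number beyond the scatter, although the step is modest and both compounds show low inhibition. Nothing available explains the step.

Going by these compounds, the change swaps the ring and adds the methyl ester together, so their separate contributions remain open. It is also unclear how a plain benzyl group or a carboxylic acid in place of the ester would read.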